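Ring opening at the amide: compound 1 to compound 4

This account rests on a few compounds, and the source may have more. Where it says the series, first, only, none or still open, it means among the compounds named here.

Compound 1 `O=C(O)[C@@H]1CCCN1C(=O)CN(c1nc(Cl)nc2[nH]cnc12)C1CC1` is the free acid of the series. In a functional assay on the whole organism (Tail, strain ICR) with Mus musculus as the target, in the tail flick test, with a stated time of 150 min, at a dose of 25 umol/kg by the oral route (on this read-out lower numbers stand for a weaker effect and higher numbers for a stronger effect at the one dose given), compound 1 gives 7.29%. Its benzyl ester, compound 2 `O=C(OCc1ccccc1)[C@@H]1CCCN1C(=O)CN(c1nc(Cl)nc2[nH]cnc12)C1CC1`, gives 31.1% in that assay. Compound 3 `O=C(CN(c1ncnc2c1ncn2C1CCCCO1)C1CC1)N[C@@H](CC(=O)OCc1ccccc1)C(=O)OCc1ccccc1` differs from compound 1 in several places. In that assay compound 3 gives 0.06%. Among the three numbers compound 1 stands second highest; its gap to compound 3 lies within the scatter, its gap to compound 2 lies beyond it. Among the measured compounds shown here, the only step between compounds that differ in a single place is a number 23.8 percentage points higher from compound 1 to compound 2 (beyond the scatter), a modest rise obtained with benzyl in place of hydrogen on an oxygen next to a carbonyl group.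

Compound 4 `O=C(O)CNC(=O)CN(c1nc(Cl)nc2[nH]cnc12)C1CC1` differs from compound 1 by (carboxymethyl)amino in place of 2-carboxypyrrolidin-1-yl on a carbonyl carbon. For the measured compounds named here, no measured step addresses this change: the one step recorded concerns the acid's ester and leaves the 2-carboxypyrrolidin-1-yl group intact, so it offers no direct guide. With the carboxylic acid retained in compound 4, the number is expected to stay near that of compound 1, and the expected step of a number 0.7 percentage points higher from compound 1 to compound 4 (within the scatter) is none beyond the scatter. Compound 4 is therefore estimated at 8%, with a range from 0% to 22%.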

Compound 4, a percentage reported as activity, at one dose (the size of the read-out at that dose, not a potency): 9.08%
Estimate against measurement, compound 4: 1.1 percentage points below, and the stated range covers the measured number.
By their numbers in this assay, from the lowest: compounds 3, 1 and 4 (each within the scatter of the next); then compound 2.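

In this assay, (carboxymethyl)amino in place of 2-carboxypyrrolidin-1-yl on a carbonyl carbon gives a number 1.8 percentage points higher from compound 1 to compound 4 (within the scatter) and so shows that, with the carboxylic acid kept, the five-membered ring and the defined stereocentre of the leaving group can be given up without a step beyond the scatter. Among the compounds shown here, the earlier single-place step, a number 23.8 percentage points higher from compound 1 to compound 2 (beyond the scatter), left this group intact, so this is the first reading of the position on the carbonyl carbon, and it is a reading among free acids at the low end of the numbers, with compound 1 at 7.29% and compound 4 at 9.08%. No measurement at hand bears on why the two free acids read alike.

Open, on these data alone, is whether benzyl on the acid oxygen of compound 4 brings a rise like the one seen for the ester of compound 1, which would show whether that step carries over to the open chain. Also open, as far as these compounds go, is how the read-out responds at this place to a longer chain such as (2-carboxyethyl)amino, or to a six-membered piperidine-2-carboxylic acid ring.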